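The source may report more compounds than this note shows. Statements on the series, on what has been measured and on what is new or still open speak of the compounds shown alone.

Working notes on the series. Compound 1 `O=c1[nH]c2cccnc2c(=O)n1O` gives 525000 nM in an assay on isolated protein for inhibition of CCR4-NOT transcription complex subunit 7 (Homo sapiens), read by fluorescence; on this read-out lower numbers stand for stronger inhibition and higher numbers for weaker inhibition. Compound 2 `O=c1[nH]c2ncn(Cc3ccncc3)c2c(=O)n1O` gives 23300 nM in this assay, and compound 3 `O=c1[nH]c2ncn(C3CCCCC3)c2c(=O)n1O` gives 28200 nM in this assay. Compound 3 holds the second highest of the three numbers: its nearest neighbour is compound 2, within the usual scatter, so no order between those two is read, while the number of compound 1 lies far above it, beyond the scatter. Among the compounds with values here, compound 1 carries a different core, so no single step connects it to compound 3.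

Compound 4 `Cn1cnc2[nH]c(=O)n(O)c(=O)c21` has not yet been measured in this assay. Against compound 3 the change is methyl in place of cyclohexyl on an aromatic nitrogen. The two groups measured so far on this aromatic nitrogen, in compound 2 and compound 3, sit close together in this assay; nothing measured shows what a methyl does there. A modest step toward a higher number is expected, a 2.8-fold higher number from compound 3 to compound 4 (0.45 log units; beyond the scatter). Compound 4 is expected to give 80000 nM in this assay, with a range from 25000 nM to 300000 nM.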

Compound 4, half-maximal inhibitory concentration: 251000 nM
Compound 4: middle estimate off by 3.1-fold (0.50 log units), on the low side; measured number inside the range.
By their numbers in this assay, from the lowest: compounds 2 and 3 (each within the scatter of the next); then compound 4; then compound 1.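

The group on this aromatic nitrogen does matter in this assay, which compound 2 and compound 3 alone, sitting within the scatter of each other, could not show. Methyl in place of cyclohexyl gives an 8.9-fold higher number from compound 3 to compound 4 (0.95 log units; beyond the scatter) and the loss of pyridin-4-yl from the saturated chain carbon gives an 11-fold higher number from compound 2 to compound 4 (1.03 log units; beyond the scatter) so both larger ring-bearing groups stand on the lower-number side of methyl, each step beyond the scatter. No measurement at hand bears on the reason for these steps.

The compounds shown leave open whether the ring itself or merely the carbon count carries the effect, which an open hexyl chain would separate from cyclohexyl. They also leave open what an amine or a carboxylic acid on the end of a longer chain would do at this nitrogen.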